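Lipophilicity notes: hexyl in place of ethoxy on the core

This account rests on a few compounds, and the source may have more. Where it says the series, first, only, none or still open, it means among the compounds named here.

Measured so far:
compound 1 `CCCCCOc1ccc(-c2[nH]c3ccccc3c2C2=C(Br)C(=O)NC2=O)cc1` — 4.2
compound 2 `CCOc1ccc2[nH]c(-c3ccccc3)c(C3=C(Br)C(=O)NC3=O)c2c1` — 2.77
compound 3 `CCOc1ccc2[nH]c(-c3ccc(OC)cc3)c(C3=C(Br)C(=O)NC3=O)c2c1` — 2.77

In a physicochemical assay for lipophilicity (on this read-out higher numbers stand for higher lipophilicity and lower numbers for lower lipophilicity), compound 2 gives 2.77, and compound 3 gives 2.77 in this assay. Compound 2 stands level with compound 3 at the digits shown; together they sit at the low end of the three numbers. The remaining compound, compound 1, gives 4.2 in this assay, higher than compound 2 and beyond the scatter, but compound 1 differs from compound 2 in more than one place, so no single step can be read from that pair.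

Compound 4 `CCCCCCc1ccc2[nH]c(-c3ccccc3)c(C3=C(Br)C(=O)NC3=O)c2c1` is not yet measured. It differs from compound 2 as follows: hexyl in place of ethoxy on an aromatic carbon

Going by the values given here, the only single step measured is no change at the digits printed from compound 2 to compound 3 (within the scatter). It concerns a different place and a different kind of change, so it does not speak to the present step. Among the compounds with values here, no measured step covers the exchange of an alkoxy group for an alkyl chain of six carbons.

On the counted change alone, a gain of three heavy atoms and loss of the one acceptor, compound 4 is expected to come out higher than compound 2 in this assay, by a step estimated at a number 2.23 log units higher from compound 2 to compound 4 (beyond the scatter). The estimate for compound 4 in this assay is 5, with a range from 4.3 to 5.7.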

Compound 4, partition coefficient: 4.39
Beside the measured number, compound 4's estimate is 0.61 log units above it; the range from low to high includes it.
By their numbers in this assay, from the lowest: compounds 2 and 3 (each within the scatter of the next); then compounds 1 and 4 (each within the scatter of the next).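

In this assay the exchange of ethoxy for hexyl on an aromatic carbon of the shared core gives a number 1.62 log units higher from compound 2 to compound 4 (beyond the scatter) and is the only step shown at this position. The other step shown, no change at the digits printed from compound 2 to compound 3 (within the scatter) and within the scatter, concerns methoxy in place of hydrogen at a different place in the molecule, so it says nothing about this position. The new step shows that at this position, meta to a fused ring and para to a fused ring, one exchange moves the number beyond the scatter, while the 3 heavy atoms and 1 hydrogen-bond acceptor of ethoxy leave and the 6 heavy atoms of hexyl enter; no measurement at hand explains the size of this step.

Going by these compounds alone, the single step cannot separate the longer chain from the loss of the oxygen, and a hexyloxy group or an ethyl chain at the same position would bear on that question. As far as these compounds go, it also remains open whether the step holds with the methoxy group of compound 3 present, and how an amine or a carboxylic acid at this position would read.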